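Swapping the benzimidazole on sulfur for a smaller ring

This account rests on a few compounds, and the source may have more. Where it says the series, first, only, none or still open, it means among the compounds named here.

Measured so far in a functional assay on PC-3 cells (Homo sapiens) for antiproliferative activity, read by MTT assay, with a stated time of 48 h; on this read-out lower numbers stand for stronger inhibition and higher numbers for weaker inhibition:
- compound 1 `COc1ccc(CN(C(=O)CCCCSc2nc3ccccc3o2)c2cc(OC)c(OC)c(OC)c2)cc1` gives 45600 nM
- compound 2 `COc1ccc(CN(C(=O)CSc2nnnn2C)c2cc(OC)c(OC)c(OC)c2)cc1` gives 10500 nM
- compound 3 `COc1ccc(CN(C(=O)CSc2nc3ccccc3[nH]2)c2cc(OC)c(OC)c(OC)c2)cc1` gives 14400 nM

All three compounds share the same core; they differ only in the group that hangs on the sulfur of the side chain. On the numbers above, compound 3 stands second highest of three. Its nearest neighbour is compound 2, and the gap between them lies within the usual scatter of this assay; the step of a 1.4-fold higher number from compound 2 to compound 3 (0.14 log units; within the scatter) shows that replacing one ring on the sulfur with another left the read-out essentially unchanged. Compound 1, with a longer chain, stands further away and beyond the scatter.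

Compound 4 `COc1ccc(CN(C(=O)CSC2=CN=NC2C)c2cc(OC)c(OC)c(OC)c2)cc1` is the next step from compound 3. The change is a group of 6 heavy atoms (4 carbon, 2 nitrogen; one five-membered non-aromatic ring with 2 hetero atoms) in place of a group of 9 heavy atoms (7 carbon, 2 nitrogen; one five-membered aromatic ring with 2 hetero atoms, one six-membered aromatic ring of carbon only), on a sulfur. Among the measured compounds shown here, the only measured step that bears on it is the one from compound 2 to compound 3, which was small, so another exchange of the group on sulfur is expected to move this assay little, if at all, beyond the scatter: the step of a 1.0-fold higher number from compound 3 to compound 4 (0.02 log units; within the scatter) is expected to be modest. Compound 4 is therefore estimated at 15000 nM, with a range from 5000 nM to 45000 nM.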

Compound 4, half-maximal inhibitory concentration: 45000 nM
Beside the measured number, compound 4's estimate is 3.0-fold (0.48 log units) below it; the measured number falls inside the stated range.
By their numbers in this assay, from the lowest: compounds 2 and 3 (each within the scatter of the next); then compounds 4 and 1 (each within the scatter of the next).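

Exchanges on this sulfur are not always silent in this assay: the earlier swap of one aromatic group for another stayed small, at a 1.4-fold higher number from compound 2 to compound 3 (0.14 log units; within the scatter), but the non-aromatic ring gives a 3.1-fold higher number from compound 3 to compound 4 (0.49 log units; beyond the scatter) and also a 4.3-fold higher number from compound 2 to compound 4 (0.63 log units; beyond the scatter). Heavy-atom count does not sort these results, since the second of those steps leaves the count unchanged and the number still rises, while the step from compound 2 to compound 3 adds heavy atoms and stays within the scatter. Nothing available here explains the rise.

The compounds shown leave open whether a plain 1H-imidazol-2-yl group on the sulfur would behave like the aromatic groups or like the non-aromatic ring. Also open, as far as these compounds go, is what a longer chain would do with the 1H-benzimidazol-2-yl group held fixed.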